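The compounds below may be only part of what the source reports. "The series", "measured", "known", "first", "only" and "open" are said of these compounds alone.

Working notes on a series built on the core of compound 1 `COc1cc(C(=O)c2sc(-c3ccc([N+](=O)[O-])cc3)cc2N)cc(OC)c1OC` and varied in the aryl group on that core. Among the measured compounds shown here, in a functional assay on FM3A cells (Mus musculus) for antiproliferative activity (on this read-out lower numbers stand for stronger inhibition and higher numbers for weaker inhibition), compound 1 gives 64 nM, the lowest number among the three measured so far. Compound 2 `COc1cc(C(=O)c2sc(-c3ccncc3)cc2N)cc(OC)c1OC` gives 150 nM in this assay, a step of a 2.3-fold higher number from compound 1 to compound 2 (0.37 log units; beyond the scatter). Compound 3 `COc1cc(C(=O)c2sc(-c3ccc(Cl)c(Cl)c3)cc2N)cc(OC)c1OC` gives 400 nM, a step of a 6.3-fold higher number from compound 1 to compound 3 (0.80 log units; beyond the scatter); between the two other aryls the step is a 2.7-fold higher number from compound 2 to compound 3 (0.43 log units; beyond the scatter). Both measured steps away from compound 1 replace the 4-nitrophenyl group as a whole, and both raise the number.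

Compound 4 `COc1cc(C(=O)c2sc(-c3ccc(C)cc3)cc2N)cc(OC)c1OC` differs from compound 1 by methyl in place of nitro on an aromatic carbon. For the measured compounds named here, no measured step exchanges only this group, so the expectation rests on the two steps that swap 4-nitrophenyl for another aryl, each a modest rise. A rise of similar or somewhat smaller size is therefore expected for compound 4, a 2.3-fold higher number from compound 1 to compound 4 (0.37 log units; beyond the scatter), since the phenyl ring itself is kept. Compound 4 is estimated at 150 nM in this assay, with a range from 50 nM to 500 nM.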

Compound 4, half-maximal inhibitory concentration: 16 nM
The estimate for compound 4 lay 9.4-fold (0.97 log units) above the measured number, outside the stated range (below it).
By their numbers in this assay, from the lowest: compound 4; then compound 1; then compound 2; then compound 3.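

Exchanging nitro for methyl on the retained phenyl ring, para to a large group, gives (a 4.0-fold lower number from compound 1 to compound 4 (0.60 log units; beyond the scatter)) in this assay. Among the compounds shown here, this is the first change at this position to lower the number, so the nitro group is not needed for low-nanomolar activity. The 4-methylphenyl group also outperforms both other aryls, with (a 9.4-fold lower number from compound 2 to compound 4 (0.97 log units; beyond the scatter)) and (a 25-fold lower number from compound 3 to compound 4 (1.40 log units; beyond the scatter)), making compound 4 the most potent of the four; nothing available bears on the reason for this order.

From the compounds shown here alone, it remains open whether the gain is specific to methyl or would also appear with a hydrogen, an ethyl, a methoxy or an amine in the same place. A single chlorine there would also show whether the weak result for the 3,4-dichlorophenyl group depends on both chlorines.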